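Trimming the Chlorophenoxymethyl Arm of a Thiazole Acid

The source may report more compounds than this note shows. Statements on the series, on what has been measured and on what is new or still open speak of the compounds shown alone.

Of the compounds shown here, two have been measured in an in vitro functional assay on HEK285-7 cells for antagonist activity at prostaglandin D2 receptor 2 (Homo sapiens), read by BRET and beta-arrestin recruitment; a lower number here means a smaller maximal response, a higher number a larger maximal response. Compound 1 `O=C(O)Cc1sc(COc2ccc(Cl)cc2)nc1-c1ccc(Cl)cc1` gives 50% in this assay, and compound 2 `N#Cc1cc(-c2nc(C(c3ccc(F)cc3)c3ccc(F)cc3)sc2CC(=O)O)ccc1F` gives 80%. Compound 1 therefore stands lowest of the two numbers, with compound 2 lying higher by a margin beyond the usual scatter. The step to compound 3 `Cc1nc(-c2ccc(Cl)cc2)c(CC(=O)O)s1`, not yet measured in this assay, is a single change from compound 1: hydrogen in place of 4-chlorophenoxy on a saturated chain carbon bound to an aromatic carbon. Among the measured compounds shown here, no comparable step between measured compounds is available, so the size of the effect rests on expectation alone. Removing a group of this size from the core of compound 1 is expected to lower the maximal response somewhat, though a change within the scatter cannot be ruled out. Compound 3 is estimated at 40% in this assay, within a range of 10% to 70%. This estimate means a step of a number 10 percentage points lower from compound 1 to compound 3 (within the scatter).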

Compound 3, largest response reached (reported as efficacy), in percent of the reference or control that the assay uses: 50%
The estimate for compound 3 lay 10 percentage points below the measured number; the range from low to high includes it.
By their numbers in this assay, from the lowest: compounds 1 and 3 (each within the scatter of the next); then compound 2.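

Putting hydrogen in place of 4-chlorophenoxy on a saturated chain carbon bound to an aromatic carbon gives no change at the digits printed from compound 1 to compound 3 (within the scatter) in this assay. This is the first change in a single place that can be read among these compounds, and it shows that a group of 8 heavy atoms, including a six-membered aromatic ring of carbon only, can leave this position while the maximal response stays within the scatter. No evidence at hand bears on this result.

What the compounds shown leave open is whether another group on this carbon, such as methoxy, an amine or a longer chain, would leave the maximal response equally unmoved. Compound 2 differs from compound 1 in more than one place, so its higher number cannot be assigned to any single change.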